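Working notes: a methyl step in the cell growth series

The source may report more compounds than this note shows. Statements on the series, on what has been measured and on what is new or still open speak of the compounds shown alone.

compound 1 `Cc1ccc(-c2cc(N3CCC(CNS(N)(=O)=O)CC3)ncn2)cc1` 30600 nM
compound 2 `NS(=O)(=O)NCCC1CCN(c2cc(-c3ccccc3)ncn2)CC1` 53200 nM

In a functional assay on MCF7 cells (Homo sapiens) for antiproliferative activity, read by sulforhodamine B assay, with a stated time of 48 h (a lower number here means a stronger inhibitor of growth, a higher number a weaker inhibitor of growth), compound 1 gives 30600 nM and compound 2 gives 53200 nM. Compound 2 holds the highest of the two numbers; its nearest neighbour is compound 1, whose number sits within the scatter of it. Compound 3 `Cc1ccc(-c2cc(N3CCC(CCNS(N)(=O)=O)CC3)ncn2)cc1` differs from compound 2 by methyl in place of hydrogen on an aromatic carbon. Among the compounds with values here, no single-change step between measured compounds is known, so this change has no direct precedent in this assay; no shift beyond the scatter is expected. Compound 3 is expected to give 45000 nM, range 15000 nM to 130000 nM. The expected step is a 1.2-fold lower number from compound 2 to compound 3 (0.07 log units; within the scatter).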

Compound 3, concentration for 50% growth inhibition: 47500 nM
Compound 3: middle estimate off by 1.1-fold (0.02 log units), on the low side; the range from low to high includes it.
By their numbers in this assay, from the lowest: compounds 1, 3 and 2 (each within the scatter of the next).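

In this assay the change from phenyl to 4-methylphenyl now has a direct reading: a 1.1-fold lower number from compound 2 to compound 3 (0.05 log units; within the scatter) and so no shift beyond the scatter for methyl at this position. With 4-methylphenyl held, (sulfamoylamino)methyl in place of sulfamoylamino on the saturated chain gives a 1.6-fold higher number from compound 1 to compound 3 (0.19 log units; within the scatter) and again no shift beyond the scatter. No measurement here bears on why either change leaves the number within the scatter. Open, on these data alone, is whether an amine or a carboxylic acid at this position, or a longer chain carrying the sulfamoylamino group, would move the number beyond the scatter.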